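Methoxy added to the phenyl of compound 3

The source may hold more compounds than are shown below. What is called first, only, known or untested is meant among the compounds shown, and "the series" means these compounds.

Compound 3 `O=C(CCCCC1CCSS1)NCc1cn(CCCCOc2ccc3cc(-c4ccccc4)c(=O)oc3c2)nn1` gives 32.8% in a functional assay on PC-12 cells (Rattus norvegicus) for cytotoxicity, read by MTT assay, with stated times of 3 h and 2 h, tested at 5 uM (on this read-out higher numbers stand for a stronger effect at the one concentration tested and lower numbers for a weaker effect), the second highest of the three numbers at hand. Compound 1 `CCOC(=O)c1cc2ccc(OCCCn3cc(CNC(=O)CCCCC4CCSS4)nn3)cc2oc1=O` gives 32.4%, which lies within the scatter of compound 3, while compound 2 `O=C(CCCCC1CCSS1)NCc1cn(CCCCOc2ccc3ccc(=O)oc3c2)nn1` gives 52.8%. For the measured compounds named here, the one measured step, a number 20 percentage points lower from compound 2 to compound 3 (beyond the scatter), is the only one that touches this part of the molecule.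

Compound 4 `COc1ccc(-c2cc3ccc(OCCCCn4cc(CNC(=O)CCCCC5CCSS5)nn4)cc3oc2=O)cc1` differs from compound 3 by methoxy in place of hydrogen on an aromatic carbon. Going by the values given here, no measured pair bears on a methoxy, so the earlier step gives no direction for it. Compound 4 is therefore expected to show a number 0.2 percentage points higher from compound 3 to compound 4 (within the scatter) in this assay, and its value is estimated at 33%, within a range from 20% to 48%.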

Compound 4, a percentage reported as activity, at one concentration (the size of the read-out at that concentration, not a potency): 44.9%
Estimate against measurement, compound 4: 11.9 percentage points below, and the stated range covers the measured number.
By their numbers in this assay, from the lowest: compounds 1 and 3 (each within the scatter of the next); then compounds 4 and 2 (each within the scatter of the next).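

In this assay, the phenyl is not a fixed feature: replacing its hydrogen with methoxy gives a number 12.1 percentage points higher from compound 3 to compound 4 (beyond the scatter) and so reverses part of the earlier drop. Measured against the core without any aryl group, the result reads a number 7.9 percentage points lower from compound 2 to compound 4 (within the scatter), so the loss seen with phenyl does not carry over to 4-methoxyphenyl. Nothing available explains this shift. The compounds shown leave open whether hydroxyl or a chlorine atom at that place on the phenyl would move the number the same way, and whether methoxy would do so elsewhere on the ring.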